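Working notes: replacing methylsulfonyl in compound 3

A few compounds are considered here, and "the series" means these few. Any claim that something is new, unique, unknown or untested is made for them only; others in the source may bear on it.

Values in a physicochemical assay for solubility, using the shake flask method, in phosphate buffer, with a stated time of 20 h, at pH 6.5 (on this read-out higher numbers stand for higher solubility and lower numbers for lower solubility), stand as follows:
- compound 1 `CCN(CC)Cc1ccc(-c2ccc3ncc(-c4ccc([S+](C)[O-])cc4)n3n2)cc1F` gives 195000 nM as its reading
- compound 2 `CCN(CC)Cc1ccc(-c2cnc3ccc(-c4cccc([S+](C)[O-])c4)nn23)c(F)c1` gives 200000 nM as its reading
- compound 3 `C[S+]([O-])c1ccc(-c2cnc3ccc(Nc4cccc(S(C)(=O)=O)c4)nn23)cc1` gives 20000 nM as its reading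

Compound 3 at 20000 nM has the lowest number of the three, and compound 1 and compound 2 both stand beyond the scatter above it. Compound 4 `C[S+]([O-])c1ccc(-c2cnc3ccc(Nc4cccc([S+](C)[O-])c4)nn23)cc1` has not been measured. It differs from compound 3 in one place (a group of 3 heavy atoms (1 carbon, 1 oxygen, 1 sulfur; no ring) in place of a group of 4 heavy atoms (1 carbon, 2 oxygen, 1 sulfur; no ring), on an aromatic carbon), where the methylsulfonyl leaves, on an aromatic carbon of a six-membered aromatic ring of carbon only, meta to a large group. Among the measured compounds shown here, no measured pair isolates this change. For the measured compounds named here, the expectation rests on compound 1 at 195000 nM and compound 2 at 200000 nM as the only guide, since both carry the entering group and no methylsulfonyl, although both also differ from compound 3 in other ways. In this assay the expected change is upward and beyond the scatter, estimated as a 3.0-fold higher number from compound 3 to compound 4 (0.48 log units; beyond the scatter) in size. Compound 4 is estimated at 60000 nM with an expected range from 20000 nM to 180000 nM in this read-out.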

Compound 4, solubility: 190000 nM
Beside the measured number, compound 4's estimate is 3.2-fold (0.50 log units) below it; measured number above the stated range.
By their numbers in this assay, from the lowest: compound 3; then compounds 4, 1 and 2 (each within the scatter of the next).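

In this assay the matched pair gives a 9.5-fold higher number from compound 3 to compound 4 (0.98 log units; beyond the scatter) when methylsulfonyl leaves and the group of 3 heavy atoms (1 carbon, 1 oxygen, 1 sulfur; no ring) enters on the aromatic carbon, meta to a large group. Among the compounds shown here, compound 1 and compound 2 carry the entering group but also differ from compound 3 elsewhere, so this step is the first to tie a change in the read-out to this one place, with the rest of compound 3 held fixed. The step itself comes with no measurement that would explain it.

The compounds shown leave open how an amine, a carboxylic acid or a longer chain would read at this place. They also leave open whether the same exchange gives a step of this size on the core of compound 1 or compound 2.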